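Swapping a Hydroxyphenyl for a Cyclopropyl

The compounds below may be only part of what the source reports. "The series", "measured", "known", "first", "only" and "open" are said of these compounds alone.

Of the compounds shown here, two of this set have been tested so far. Compound 1 `O=C1O/C(=C\Cn2cc(-c3ccc(Br)cc3)nn2)C(OCc2ccccc2)=C1OCc1ccccc1` was examined in a functional assay on CFPAC-1 cells (Homo sapiens) for antiproliferative activity, read by MTT assay, with a stated time of 72 h; a higher number here means a weaker inhibitor, a lower number a stronger inhibitor. In this assay compound 1 reached only the limit of > 100000 nM, so no number is attached to it. Compound 2 `O=C1O[C@H]([C@@H](O)Cn2cc(-c3cccc(O)c3)nn2)C(OCc2ccccc2)=C1OCc1ccccc1` gives 54100 nM in this assay. On the numbers shown, compound 2 therefore holds the only measured value, while the other entry is a limit (the limit of > 100000 nM in this assay, at which 1 of the 2 values shown sits).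

Compound 3 `O=C1O[C@H]([C@@H](O)Cn2cc(C3CC3)nn2)C(OCc2ccccc2)=C1OCc1ccccc1` has not yet been measured. It differs from compound 2 by a single change (cyclopropyl in place of 3-hydroxyphenyl on an aromatic carbon). For the measured compounds named here, no measured pair in the set shows this step, so its size cannot be read from the data. Since compound 2 already sits at 54100 nM, the step of a 1.5-fold higher number from compound 2 to compound 3 (0.17 log units; within the scatter) is expected to be modest, either toward weaker inhibition or within the scatter. The value of compound 3 in this assay is accordingly expected at about 80000 nM, in a range from 30000 nM to 250000 nM, with a real chance that only a limit is reported.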

Compound 3, half-maximal inhibitory concentration: 47700 nM
For compound 3 the middle estimate is 1.7-fold (0.22 log units) above the measured one, within the range that was stated.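

In this assay, the exchange of 3-hydroxyphenyl for cyclopropyl on this aromatic carbon of the five-membered aromatic ring with 3 nitrogen is a 1.1-fold lower number from compound 2 to compound 3 (0.05 log units; within the scatter), so the read-out does not separate the two groups at this position. The step gives the first measured view of this position, and the two compounds cannot be told apart even though the leaving group has 7 heavy atoms, a six-membered aromatic ring and 1 hydrogen-bond donor, while the entering group has 3 heavy atoms, a three-membered non-aromatic ring and 0 hydrogen-bond donors. In this pair, therefore, neither the six-membered aromatic ring nor its hydroxyl is needed to keep the value where it stands, and nothing measured here offers a reason for this.

For the compounds shown here, compound 1, whose > 100000 nM is a limit of the assay and not a number, differs from the other compounds in more than one place, so no step to it can be read. From the compounds shown here alone, whether any group at this position can move the value beyond the scatter remains open, and an amine, a carboxylic acid or a longer chain on the same carbon would address that question.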